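This account rests on a few compounds, and the source may have more. Where it says the series, first, only, none or still open, it means among the compounds named here.

Of the compounds shown here, three built on one shared core have so far been measured in a physicochemical assay for solubility, read by HPLC, in phosphate buffer, with a stated time of 4 h, at pH 7.4; a lower number here means a less soluble compound, a higher number a more soluble compound. Compound 1 `Cc1cc(/C=C/C#N)cc(C)c1Oc1cc(Nc2ccc(C#N)cc2)c(N)cc1C(=O)NN` gives 2.4 ug/mL. Compound 2 `Cc1cc(/C=C/C#N)cc(C)c1Oc1cc(Nc2ccc(C#N)cc2)c(N)cc1C(N)=O` gives 0.63 ug/mL. Compound 3 `Cc1cc(/C=C/C#N)cc(C)c1Oc1cc(Nc2ccc(C#N)cc2)c(N)cc1C(=O)NCCC(F)F` gives 6.59 ug/mL, the highest number of the three. The steps between them were a 3.8-fold lower number from compound 1 to compound 2 (0.58 log units; beyond the scatter), a 2.7-fold higher number from compound 1 to compound 3 (0.44 log units; beyond the scatter) and a 10-fold higher number from compound 2 to compound 3 (1.02 log units; beyond the scatter). Compound 4 `COC(=O)c1cc(N)c(Nc2ccc(C#N)cc2)cc1Oc1c(C)cc(/C=C/C#N)cc1C` has not yet been measured; it differs from compound 3 in one place: methoxy in place of (3,3-difluoropropyl)amino on a carbonyl carbon. For the measured compounds named here, no measured step makes exactly this change, but all three measured steps alter the group on the same carbonyl carbon, and the smallest group there, in compound 2, went with the lowest number, 0.63 ug/mL. Since the methoxy of compound 4 is closer in size to the hydrogen of compound 2 than to the 3,3-difluoropropyl of compound 3, the number for compound 4 is expected to fall, giving an estimated 4.4-fold lower number from compound 3 to compound 4 (0.64 log units; beyond the scatter). Compound 4 is therefore estimated at 1.5 ug/mL, with a likely range from 0.4 ug/mL to 5 ug/mL.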

Compound 4, solubility: 1.21 ug/mL
Estimate against measurement, compound 4: 1.2-fold (0.09 log units) above; measured number inside the range.
By their numbers in this assay, from the lowest: compounds 2, 4 and 1 (each within the scatter of the next, the first and the last beyond it); then compound 3.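

In this assay, for the compounds shown here, methoxycarbonyl is the first group here with no nitrogen on the carbonyl carbon, and a 5.4-fold lower number from compound 3 to compound 4 (0.74 log units; beyond the scatter) sets it clearly apart from (3,3-difluoropropyl)carbamoyl. It does not separate from the two small nitrogen-bearing groups, with a 1.9-fold higher number from compound 2 to compound 4 (0.28 log units; within the scatter) and a 2.0-fold lower number from compound 1 to compound 4 (0.30 log units; within the scatter), so removing the nitrogen from this carbonyl carbon does not by itself separate compound 4 from compound 1 or compound 2, and among the four compounds only compound 3 stands apart from all the others. No measurement shown explains these differences.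

On these data alone, it remains open whether the higher number of compound 3 goes with the length of its chain or with its two fluorine atoms, a question that a plain propyl chain on the same nitrogen could address. Also open, as far as these compounds go, is where a carboxylic acid at this carbonyl carbon would fall.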